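The source may hold more compounds than are shown below. What is called first, only, known or untested is meant among the compounds shown, and "the series" means these compounds.

Measured in an ADME assay on L6 cells (Rattus norvegicus) for cytotoxicity; on this read-out higher numbers stand for weaker inhibition and lower numbers for stronger inhibition:
- Compound 1 `O=C(NCCCCn1cnc([N+](=O)[O-])n1)c1ccc(C(F)(F)F)cc1`: 104000 nM
- Compound 2 `O=C(NCCCn1cnc([N+](=O)[O-])n1)c1cccc(C(F)(F)F)c1`: > 292000 nM

Compound 2 stands at a limit, not at a number, with > 292000 nM in this assay. Compound 3 `O=C(NCCCn1cnc([N+](=O)[O-])n1)c1cc(C(F)(F)F)cc(C(F)(F)F)c1` carries one change from it: trifluoromethyl in place of hydrogen on an aromatic carbon. Among the compounds with values here, no measured step shows what this change does. A moderate move toward stronger inhibition in this assay is expected, though another limit remains possible. Within the data shown here, the estimate is anchored on compound 1 at 104000 nM, the only numerical reading so far. The expected change is an at least 2.2-fold lower number from compound 2 to compound 3 (0.35 log units; beyond the scatter). For compound 3 the estimated value is 130000 nM, with an expected range of 45000 nM to 300000 nM.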

Compound 3, half-maximal inhibitory concentration: 187000 nM
Compound 3: the middle estimate sits 1.4-fold (0.16 log units) below what was measured, and the stated range covers the measured number.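

In this assay the second trifluoromethyl, meta to a trifluoromethyl group, gives an at least 1.5-fold lower number from compound 2 to compound 3 (0.19 log units; that floor lies within the scatter) and so yields a number at this position where only a limit stood before. Read as a floor, this step stays within the scatter and does not by itself establish a shift toward stronger inhibition. Compound 2 stands at a limit and not at a number, so the true size of the step stays unknown: the limit of > 292000 nM in this assay, at which 1 of the 3 values shown sits.

On these data alone, whether a chlorine, a nitrile or an amine at this place would move the number the same way remains open. So does what a longer chain would do on the core of compound 3.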